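Methoxy Added to a Weak Cytotoxic Series

A few compounds are considered here, and "the series" means these few. Any claim that something is new, unique, unknown or untested is made for them only; others in the source may bear on it.

Measured compounds:
compound 1 `COCOCc1cc(OC)ccc1-c1cc2ccccc2c(=O)[nH]1`: 75500 nM
compound 2 `C=CCn1c(-c2ccc(OC)cc2C=O)cc2ccccc2c1=O`: 65500 nM
compound 3 `COCOCc1cc(OC)c(OC)cc1-c1cc2ccccc2c(=O)[nH]1`: 87700 nM

All three were tested in a functional assay on SK-OV-3 cells (Homo sapiens) for cytotoxicity, read by MTT assay, with a stated time of 48 h; a lower number here means a stronger inhibitor, a higher number a weaker inhibitor. Compound 1 gives 75500 nM in this assay, and compound 3 `COCOCc1cc(OC)c(OC)cc1-c1cc2ccccc2c(=O)[nH]1` gives 87700 nM. Between them stands one change, (methoxy in place of hydrogen on an aromatic carbon), which made a step of a 1.2-fold higher number from compound 1 to compound 3 (0.07 log units; within the scatter). Compound 2 gives 65500 nM; the difference between its core and that of compound 1 is not broken down here.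

Compound 4 `C=CCn1c(-c2cc(OC)c(OC)cc2C=O)cc2ccccc2c1=O` has not yet been measured. It differs from compound 2 by methoxy in place of hydrogen on an aromatic carbon, the same kind of change as from compound 1 to compound 3, though here the new methoxy sits para to a formyl group rather than para to a (methoxymethoxy)methyl group. Resting on the step of a 1.2-fold higher number from compound 1 to compound 3 (0.07 log units; within the scatter), the step from compound 2 to compound 4 is expected to be about a 1.1-fold higher number from compound 2 to compound 4 (0.06 log units; within the scatter). Compound 4 is therefore estimated at 75000 nM, between 35000 nM and 160000 nM.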

Compound 4, half-maximal inhibitory concentration: 85500 nM
The estimate for compound 4 lay 1.1-fold (0.06 log units) below the measured number; the range from low to high includes it.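

In this assay, methoxy in place of hydrogen on an aromatic carbon gave a step of a 1.3-fold higher number from compound 2 to compound 4 (0.12 log units; within the scatter). Set beside the earlier case, the change carried over from one core to the other as closely as these data can tell: the same change on two cores in this assay, a 1.2-fold higher number (0.07 log units; within the scatter) from compound 1 to compound 3 and a 1.3-fold higher number (0.12 log units; within the scatter) from compound 2 to compound 4, 1.1-fold (0.05 log units) apart, within the scatter of two such steps. Within the data shown here, since both steps lie within the scatter, this shows only that the change made no readable difference on either core; it does not show a real shift in either direction, nor does it speak for other cores or other places on the ring.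

The compounds shown leave open whether a different group at this place, such as an amine or a carboxylic acid, would give a step beyond the scatter. From the compounds shown here alone, it is also open whether a longer alkoxy chain would behave alike on the core of compound 1 and the core of compound 2.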